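The compounds below may be only part of what the source reports. "The series", "measured", "known", "first", "only" and "open" are said of these compounds alone.

Measured so far:

- Compound 1, `O=P(O)(O)OP(=O)(O)OP(=O)(O)OC[C@H]1O[C@@H](c2nc3c(F)cc(Cl)cc3s2)[C@H](O)[C@@H]1O`: 7 nM
- Compound 2, `O=P(O)(O)OP(=O)(O)OP(=O)(O)OC[C@H]1O[C@@H](c2nc3cc(C(F)(F)F)ccc3s2)[C@H](O)[C@@H]1O`: 10 nM
- Compound 3, `O=c1c2cc(F)ccc2ccn1[C@@H]1O[C@H](COP(=O)(O)OP(=O)(O)OP(=O)(O)O)[C@@H](O)[C@H]1O`: 5 nM

All three were read in a functional assay for agonist activity at P2Y purinoceptor 2 (Homo sapiens), read by FLIPR; on this read-out lower numbers stand for an effect already at smaller amounts and higher numbers for an effect only at larger amounts of compound. Compound 2 gives the highest of the three numbers, yet its gap to compound 1 and its gap to compound 3 both lie within the usual scatter, so the three compounds are not separated by these measurements. Going by the values given here, no pair among them differs in a single place, so no step between measured compounds is available, and the substituent on the fused benzo ring has not been varied in isolation.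

Compound 4, `O=P(O)(O)OP(=O)(O)OP(=O)(O)OC[C@H]1O[C@@H](c2nc3ccccc3s2)[C@H](O)[C@@H]1O`, has not yet been measured in this assay. Against compound 2 the change is hydrogen in place of trifluoromethyl on an aromatic carbon. Compound 1 and compound 2 carry different substitution on that ring and give numbers within the scatter of each other, which hints that this ring tolerates some variation, but a bare ring has not been tested. The expected step from compound 2 to compound 4 is a 1.5-fold higher number from compound 2 to compound 4 (0.18 log units; within the scatter), a small rise that may not exceed the scatter. For compound 4 the estimated value in this assay is 15 nM, with a range from 5 nM to 50 nM.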

Compound 4, half-maximal effective concentration: 22 nM
The estimate for compound 4 lay 1.5-fold (0.17 log units) below the measured number; low and high end bracket the measured number.
By their numbers in this assay, from the lowest: compounds 3, 1 and 2 (each within the scatter of the next); then compound 4.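

In this assay, going by these compounds alone, hydrogen in place of trifluoromethyl, on an aromatic carbon of the six-membered aromatic ring of carbon only, gives a 2.2-fold higher number from compound 2 to compound 4 (0.34 log units; beyond the scatter) and so provides the first single-place step. The earlier compounds shown here could not show this: their numbers lay within the scatter of one another and they differ in more than one place, so they gave no sign that a substituent at this carbon counts. The step is modest but beyond the scatter, which shows that trifluoromethyl at this position is not interchangeable with hydrogen on this core, although the compounds offer no explanation for the difference.

From the compounds shown here alone, it remains open whether the number seen with trifluoromethyl depends on that group specifically, or whether a nitrile, a methoxy group or an amine on the same aromatic carbon would give a similar number. Also open, going by these compounds, is whether the same exchange would give a step of similar size on a ring that already carries other substituents, as in the core of compound 1, or at another carbon of this ring.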